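Changing the distal aryl substituent on a shared core

The source may hold more compounds than are shown below. What is called first, only, known or untested is meant among the compounds shown, and "the series" means these compounds.

Compound 3 `COc1ccccc1-c1ccc(Cc2c(C)c3ccc(OCC(O)CN4CCC(C(N)=O)CC4)cc3oc2=O)cc1` gives 91600 nM in an ADME assay on A549 cells (Homo sapiens) for cytotoxicity, read by CellTiter-Glo (on this read-out lower numbers stand for higher toxicity in this test and higher numbers for lower toxicity in this test), the highest of the three numbers shown, though its gaps to compound 1 `Cc1c(Cc2ccc(C(F)(F)F)cc2)c(=O)oc2cc(OCC(O)CN3CCC(C(N)=O)CC3)ccc12` at 89300 nM and compound 2 `Cc1c(Cc2ccc(OC(F)(F)F)cc2)c(=O)oc2cc(OCC(O)CN3CCC(C(N)=O)CC3)ccc12` at 68200 nM both lie within the scatter, as a 1.0-fold higher number from compound 1 to compound 3 (0.01 log units; within the scatter) and a 1.3-fold higher number from compound 2 to compound 3 (0.13 log units; within the scatter) show. Compound 4 `Cc1c(Cc2ccc(-c3ccc(C(F)(F)F)cc3)cc2)c(=O)oc2cc(OCC(O)CN3CCC(C(N)=O)CC3)ccc12` differs from compound 3 by 4-(trifluoromethyl)phenyl in place of 2-methoxyphenyl on an aromatic carbon. Among the measured compounds shown here, the steps that bear on this swap, a 1.0-fold higher number from compound 1 to compound 3 (0.01 log units; within the scatter) and a 1.3-fold higher number from compound 2 to compound 3 (0.13 log units; within the scatter), exchanged groups at the same place and moved nothing beyond the scatter, so no step beyond the scatter is expected in this assay for compound 4 either. Compound 4 is therefore expected to give 80000 nM, within 40000 nM to 160000 nM, a step of a 1.1-fold lower number from compound 3 to compound 4 (0.06 log units; within the scatter).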

Compound 4, half-maximal cytotoxic concentration: > 100000 nM
Compound 4 gave a limit, no number (the forecaster's own chance of this, stated with the estimate: 15%); at least 1.2-fold (0.09 log units) between middle value and limit.
By their numbers in this assay, from the lowest: compounds 2, 1 and 3 (each within the scatter of the next). At a limit, above all of these: compound 4.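

Compound 4 gives a limit, not a number, in this assay: the limit of > 100000 nM in this assay, at which 1 of the 4 values shown sits. Only floors can be read from it, and all lie within the scatter: an at least 1.0-fold higher number from compound 3 to compound 4 (0.03 log units; that floor lies within the scatter) and an at least 1.4-fold higher number from compound 2 to compound 4 (0.16 log units; that floor lies within the scatter) and an at least 1.1-fold higher number from compound 1 to compound 4 (0.04 log units; that floor lies within the scatter) are the steps. The position therefore carries 4-(trifluoromethyl)phenyl with no shift beyond the scatter shown, while the true size of each step stays unknown. As far as these compounds go, whether an amine or a carboxylic acid at this position would move the read-out remains open. So does whether any group here gives a step beyond the scatter.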